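The source may report more compounds than this note shows. Statements on the series, on what has been measured and on what is new or still open speak of the compounds shown alone.

Measured compounds:
compound 1 `O=C(CSc1ccc(Br)cc1)N1N=C(c2cc3ccccc3oc2=O)C[C@@H]1c1ccc(C(F)(F)F)cc1` — 12700 nM
compound 2 `O=C(CSc1ccc([N+](=O)[O-])cc1)N1N=C(c2cc3ccccc3oc2=O)C[C@@H]1c1ccc(C(F)(F)F)cc1` — 7760 nM
compound 3 `O=C(CSCc1ccco1)N1N=C(c2cc3ccccc3oc2=O)C[C@@H]1c1ccc(C(F)(F)F)cc1` — 11200 nM

In a functional assay on HepG2 cells (Homo sapiens) for cytotoxicity, read by MTT assay, with a stated time of 48 h (on this read-out higher numbers stand for weaker inhibition and lower numbers for stronger inhibition), compound 1 gives the highest of the three numbers, yet all three sit close together: a 1.1-fold lower number from compound 1 to compound 3 (0.05 log units; within the scatter) and a 1.6-fold lower number from compound 1 to compound 2 (0.21 log units; within the scatter), and between the other two, a 1.4-fold higher number from compound 2 to compound 3 (0.16 log units; within the scatter). Every measured step changes only the group on the sulfur; the six-membered aromatic ring of carbon only on the shared core carries trifluoromethyl in all three.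

Compound 4 `O=C(CSc1ccc(Br)cc1)N1N=C(c2cc3ccccc3oc2=O)C[C@@H]1c1ccccc1` differs from compound 1 at that untouched position: hydrogen in place of trifluoromethyl on an aromatic carbon. Among the measured compounds shown here, no measured step bears directly on this change. What the series does show is that the three variations tried so far all stayed within the scatter, with no step beyond it in either direction. With nothing to argue for a shift, the expectation for compound 4 is a number close to that of compound 1, the step being estimated as a 1.0-fold higher number from compound 1 to compound 4 (0.01 log units; within the scatter). Compound 4 is thus estimated at 13000 nM, with a range from 5000 nM to 35000 nM.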

Compound 4, half-maximal inhibitory concentration: 14500 nM
Beside the measured number, compound 4's estimate is 1.1-fold (0.05 log units) below it; the range from low to high includes it.
By their numbers in this assay, from the lowest: compounds 2, 3, 1 and 4 (each within the scatter of the next).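

In this assay, among the compounds shown here, going from 4-(trifluoromethyl)phenyl to phenyl gives a 1.1-fold higher number from compound 1 to compound 4 (0.06 log units; within the scatter) and so brings the first variation at this position, which was held constant in the earlier compounds. Like the steps on the sulfur, this one stays within the scatter, so with 4-bromophenyl on the sulfur the number does not depend measurably on trifluoromethyl being present. No supporting data on this position are available to interpret the step further.

The phenyl form is shown only with 4-bromophenyl on the sulfur, so it remains open whether the same holds with 4-nitrophenyl or (furan-2-yl)methyl there. Also open, on these data alone, is whether a different kind of group at this place on the aromatic ring, such as an amine or a carboxylic acid, would move the number beyond the scatter.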